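The source may hold more compounds than are shown below. What is called first, only, known or untested is meant among the compounds shown, and "the series" means these compounds.

Measured in a physicochemical assay for lipophilicity; a lower number here means a more polar compound, a higher number a more lipophilic compound:
compound 1 `Cc1csc2cc([C@H](C)Nc3ncnc(N)c3C#N)c(-c3cccc(CC4CCN(C(C)C)CC4)c3)c(=O)n12`: 1.1
compound 2 `Cc1csc2cc([C@H](C)Nc3ncnc(N)c3C#N)c(Cc3cccc(CN4CCC4)c3)c(=O)n12`: 0.5
compound 3 `Cc1csc2cc([C@H](C)Nc3ncnc(N)c3C#N)c(Cc3cccc(CN)c3)c(=O)n12`: -0.3

Compound 3 stands lowest of the three, and its gaps to compound 2 and to compound 1 both lie beyond the scatter. The next compound, compound 4 `Cc1csc2cc([C@H](C)Nc3ncnc(N)c3C#N)c(-c3ccccc3)c(=O)n12`, has not yet been measured. It carries phenyl in place of 3-(aminomethyl)benzyl on an aromatic carbon, and the change is phenyl in place of 3-(aminomethyl)benzyl on an aromatic carbon in full.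

For the measured compounds named here, only one measured step touches this side chain. It is a number 0.80 log units lower from compound 2 to compound 3 (beyond the scatter) and it puts amino in place of azetidin-1-yl. That step is an imperfect guide, as every measured compound keeps a nitrogen in the side chain and the entering phenyl has none, so no measurement shows this change directly. Compound 1 also keeps that nitrogen, and its value of 1.1 is the highest so far. Gaining amino took the number down in the measured step, so removing the whole aminomethyl-bearing chain should move it the other way, and by more. The expected change is a number 2.90 log units higher from compound 3 to compound 4 (beyond the scatter) and this estimate carries a wide margin. Compound 4 is therefore expected at 2.6 (estimated range 1.9 to 3.3).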

Compound 4, distribution coefficient: 2.7
Estimate against measurement, compound 4: 0.10 log units below; measured number inside the range.
By their numbers in this assay, from the lowest: compound 3; then compound 2; then compound 1; then compound 4.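

In this assay, the number rises a number 1.60 log units higher from compound 1 to compound 4 (beyond the scatter), a change that only strips the (1-isopropylpiperidin-4-yl)methyl group from the phenyl ring and leaves that ring on the core. For the compounds shown here, this is the first direct view of a bare phenyl at this position, and it shows that a large nitrogen-bearing substituent on the ring is not needed to reach the highest numbers seen so far, since compound 4 stands beyond the scatter above compound 1. The rise a number 3.00 log units higher from compound 3 to compound 4 (beyond the scatter) is larger still, but that step swaps 3-(aminomethyl)benzyl for phenyl, so it removes the amine and the carbon linking the ring to the core together, and no supporting measurement explains either shift.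

That larger step removes the amine and the linking carbon together, and the data do not separate the two. A plain benzyl group at this position would separate them. Also open, going by these compounds, is how a phenyl ring carrying only an aminomethyl group, or a carboxylic acid in its place, would compare with the bare phenyl of compound 4.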